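Amide nitrogen substituent and tolerated concentration on the shared core

This account rests on a few compounds, and the source may have more. Where it says the series, first, only, none or still open, it means among the compounds named here.

Measured so far in an ADME assay on MT4 cells (Homo sapiens) for cytotoxicity, read by MTT assay; a higher number here means that more compound is tolerated, a lower number that less compound is tolerated:
compound 1 `Cc1cc(C)cc(S(=O)(=O)c2c(C(=O)Nc3cccc(O)c3)[nH]c3ccc(Cl)cc23)c1` gives 24600 nM
compound 2 `Cc1cc(C)cc(S(=O)(=O)c2c(C(=O)Nc3ccc(O)cc3)[nH]c3ccc(Cl)cc23)c1` gives 18100 nM
compound 3 `Cc1cc(C)cc(S(=O)(=O)c2c(C(=O)NCc3ccccc3N)[nH]c3ccc(Cl)cc23)c1` gives 46200 nM

Compound 1 sits within the scatter of both other numbers: a 1.4-fold lower number from compound 1 to compound 2 (0.13 log units; within the scatter) and a 1.9-fold higher number from compound 1 to compound 3 (0.27 log units; within the scatter). Within the data shown here, the only step that passes the scatter is a 2.6-fold higher number from compound 2 to compound 3 (0.41 log units; beyond the scatter), and even that is modest.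

Compound 4 `Cc1cc(C)cc(S(=O)(=O)c2c(C(=O)NCc3ccc(CO)cc3)[nH]c3ccc(Cl)cc23)c1` is not yet measured. Relative to compound 1 the change is 4-(hydroxymethyl)benzyl in place of 3-hydroxyphenyl on an amide-type nitrogen. Among the measured compounds shown here, the steps that bear on it are the two in which a hydroxyphenyl on the amide-type nitrogen gives way to 2-aminobenzyl: a 1.9-fold higher number from compound 1 to compound 3 (0.27 log units; within the scatter) and a 2.6-fold higher number from compound 2 to compound 3 (0.41 log units; beyond the scatter). Both point towards a higher number, one within and one just beyond the scatter, and compound 4 again carries a benzyl on that nitrogen, so a small rise is expected, possibly not beyond the scatter. For compound 4 the estimate is 35000 nM, with a range from 15000 nM to 80000 nM. The step this estimate implies is a 1.4-fold higher number from compound 1 to compound 4 (0.15 log units; within the scatter), to be checked once the measurement is in hand.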

Compound 4, half-maximal cytotoxic concentration: 31100 nM
Compound 4: the middle estimate sits 1.1-fold (0.05 log units) above what was measured; low and high end bracket the measured number.
By their numbers in this assay, from the lowest: compounds 2, 1, 4 and 3 (each within the scatter of the next, the first and the last beyond it).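

In this assay, 4-(hydroxymethyl)benzyl on the amide-type nitrogen stays within the scatter of all three earlier groups: a 1.3-fold higher number from compound 1 to compound 4 (0.10 log units; within the scatter) and a 1.7-fold higher number from compound 2 to compound 4 (0.24 log units; within the scatter) and a 1.5-fold lower number from compound 3 to compound 4 (0.17 log units; within the scatter). Among these compounds, the entering group has more heavy atoms than 3-hydroxyphenyl and the same hydrogen-bond donor and acceptor counts, and this change does not separate compound 4 from compound 1, so the only gap beyond the scatter remains the one between compound 2 and compound 3. No measurement at hand accounts for these numbers.

Open, as far as these compounds go, is whether an unsubstituted benzyl, 3-(hydroxymethyl)benzyl or a carboxylic acid in place of the hydroxymethyl would stay within the same band. Compound 4 also does not settle whether the gap between compound 2 and compound 3 goes with the benzyl or with its amine.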